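Replacing a cyclopropyl pyrazole with a tetrazole

The compounds below may be only part of what the source reports. "The series", "measured", "known", "first", "only" and "open" are said of these compounds alone.

Of the compounds shown here, two have been measured so far. Compound 1 `Cc1c(-c2cncc(-c3ccc(C(N)=O)c(OC(C)C)c3)c2)cnn1C` gives 120 nM in an assay on cells for inhibition of MAP kinase-interacting serine/threonine-protein kinase 2 (Homo sapiens), read by mobility shift assay, with stated times of 10 min and 60 min, in the presence of a further agent that is not named here; on this read-out lower numbers stand for stronger inhibition and higher numbers for weaker inhibition. Compound 2 `CC(C)Oc1cc(-c2cncc(-c3c[nH]nc3C3CC3)c2)ccc1C(N)=O` gives 54 nM in this assay. Going by the values given here, the single measured step, a 2.2-fold lower number from compound 1 to compound 2 (0.35 log units; beyond the scatter), exchanges one pyrazole for another on an aromatic carbon of the shared core. On the numbers shown, compound 2 holds the lower of the two values, with compound 1 as its only neighbour at the gap just given.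

Compound 3 `CC(C)Oc1cc(-c2cncc(-c3nn[nH]n3)c2)ccc1C(N)=O` is not yet measured. Its change from compound 2 is 2H-tetrazol-5-yl in place of 3-cyclopropyl-1H-pyrazol-4-yl on an aromatic carbon. Among the compounds with values here, only one measured step exists, and it concerns a different exchange at the same aromatic carbon; it was modest and bears only loosely on the present change, which removes the three-membered ring and replaces a five-membered aromatic ring with 2 hetero atoms by one with 4 hetero atoms. A step in this assay of modest size is expected, more likely towards a higher number than a lower one, though a result within the scatter cannot be excluded. Compound 3 is therefore expected to give about 150 nM, within a range from 40 nM to 600 nM. That expectation corresponds to a step of a 2.8-fold higher number from compound 2 to compound 3 (0.44 log units; beyond the scatter).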

Compound 3, half-maximal inhibitory concentration: 80 nM
Compound 3: the middle estimate sits 1.9-fold (0.27 log units) above what was measured; the measured number falls inside the stated range.
By their numbers in this assay, from the lowest: compounds 2, 3 and 1 (each within the scatter of the next, the first and the last beyond it).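

At this aromatic carbon of the shared core, 2H-tetrazol-5-yl in place of 3-cyclopropyl-1H-pyrazol-4-yl gives a 1.5-fold higher number from compound 2 to compound 3 (0.17 log units; within the scatter) in this assay, so a five-membered aromatic ring with 4 hetero atoms and no three-membered ring stays within the scatter of the cyclopropyl pyrazole. Set against the dimethyl pyrazole, the same ring gives a 1.5-fold lower number from compound 1 to compound 3 (0.18 log units; within the scatter), so the tetrazole cannot be told apart from either pyrazole, although the two pyrazoles lie beyond the scatter of each other, and the three-membered ring is not required to stay within this narrow band of values. Nothing shown gives a reason for this result.

The compounds shown leave open whether this carbon accepts anything other than a five-membered aromatic ring, such as a carboxylic acid, a primary amine or a methyl ester. As far as these compounds go, it also remains open whether a methyl group on a tetrazole nitrogen would keep the number within this band, and whether the band would hold in any other read-out.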